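Taking the methoxy off compound 3

A few compounds are considered here, and "the series" means these few. Any claim that something is new, unique, unknown or untested is made for them only; others in the source may bear on it.

Values in a functional assay on HCT-116 cells (Homo sapiens) for antiproliferative activity, read by MTT assay, with a stated time of 72 h (a lower number here means a stronger inhibitor, a higher number a weaker inhibitor), are as follows
compound 1 `CC(C)N1C(=O)COc2ccc(-c3cnc(Cl)c(NS(=O)(=O)c4ccc(F)cc4)c3)cc21` gives 18900 nM
compound 2 `O=C1COc2ccc(-c3cnc(Cl)c(NS(=O)(=O)c4ccc(F)cc4)c3)cc2N1c1ccc(F)cc1` gives 34200 nM
compound 3 `COc1cccc(N2C(=O)COc3ccc(-c4cccc(NS(=O)(=O)c5ccc(F)cc5)c4)cc32)c1` gives > 40000 nM (a limit)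

Compound 3 stands at > 40000 nM and this is a limit of the assay, not a number. Compound 4 `O=C1COc2ccc(-c3cccc(NS(=O)(=O)c4ccc(F)cc4)c3)cc2N1c1ccccc1` has hydrogen in place of methoxy on an aromatic carbon. Going by the values given here, the only measured step (a 1.8-fold higher number from compound 1 to compound 2 (0.26 log units; within the scatter)) swaps isopropyl for 4-fluorophenyl on an amide-type nitrogen in a ring, on a core that differs from that of compound 3. It is within the scatter and bears only loosely on this change. No step beyond the scatter is therefore expected in this assay and no direction is favoured. The estimated change is a step that the limit leaves unreadable from compound 3 to compound 4 and it remains uncertain. For compound 4 the expected value is 45000 nM within an estimated range of 20000 nM to 90000 nM in this assay.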

Compound 4, half-maximal inhibitory concentration: > 40000 nM
Compound 4: no number, only a limit (the forecaster's own chance of this, stated with the estimate: 55%); the middle value is on the limit's open side.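

In this assay compound 3 and compound 4 each give only a limit of the assay, so no step between them can be read: the limit of > 40000 nM in this assay, at which 2 of the 4 values shown sit.

The compounds shown leave open whether going from 3-methoxyphenyl to phenyl changes the value in this assay at all.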